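Adding a Methoxy Group to a Weak Chalcone Analogue

The source may report more compounds than this note shows. Statements on the series, on what has been measured and on what is new or still open speak of the compounds shown alone.

Compound 1 `C=C(Br)C(=O)Nc1ccc(C(=O)/C=C/c2ccc(OC)c(OC)c2)cc1` and compound 2 `C=C(Br)C(=O)Nc1ccc(C(=O)/C=C/c2cc(OC)c(OC)c(OC)c2)cc1` share a core, and in a functional assay on FM3A cells (Mus musculus) for antiproliferative activity, with a stated time of 48 h (a lower number here means a stronger inhibitor, a higher number a weaker inhibitor), compound 1 gives 1200 nM while compound 2 gives 1800 nM. The change between them is methoxy in place of hydrogen on an aromatic carbon, and it made a 1.5-fold higher number from compound 1 to compound 2 (0.18 log units; within the scatter). Compound 3 `COc1ccccc1/C=C/C(=O)c1ccc(N)cc1` has a different core; how the two cores differ is not broken down here. In this assay compound 3 gives 25000 nM, the highest number of the three. Compound 4 `COc1cccc(/C=C/C(=O)c2ccc(N)cc2)c1OC` is the unmeasured partner of compound 3, and the change is methoxy in place of hydrogen on an aromatic carbon. This is the same kind of change as before, though the place differs: in compound 2 the new group is also meta to a methoxy group. Because a 1.5-fold higher number from compound 1 to compound 2 (0.18 log units; within the scatter) stayed within the scatter, the step from compound 3 to compound 4 is expected to be a 1.2-fold higher number from compound 3 to compound 4 (0.08 log units; within the scatter). Compound 4 is therefore estimated at 30000 nM.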

Compound 4, half-maximal inhibitory concentration: 29000 nM
Compound 4: middle estimate off by 1.0-fold (0.01 log units), on the high side; the measured number falls inside the stated range.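

On the second core, the added methoxy group gave a 1.2-fold higher number from compound 3 to compound 4 (0.06 log units; within the scatter). Set beside the earlier step, the change looks alike on the two cores: the same change on two cores in this assay, a 1.5-fold higher number (0.18 log units; within the scatter) from compound 1 to compound 2 and a 1.2-fold higher number (0.06 log units; within the scatter) from compound 3 to compound 4, 1.3-fold (0.11 log units) apart, within the scatter of two such steps. This shows that on these two cores the methoxy group left the number within the scatter, but it does not show a real gain or loss from the change, and two pairs cannot establish a rule for other cores or other places on the ring.

The compounds shown leave open whether a different group on the same aromatic ring, such as a hydroxyl or an ethoxy group, would move the number beyond the scatter. From the compounds shown here alone, how the methoxy change behaves on a third core also remains open.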